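The source may report more compounds than this note shows. Statements on the series, on what has been measured and on what is new or still open speak of the compounds shown alone.

Measured in an in vitro ADME assay on microsomes from liver (Homo sapiens) for metabolic stability, read by LC-MS; a lower number here means that the compound disappears faster, a higher number that the compound lasts longer:
- compound 1 `CCON/C(=N\C1=NC(=O)C(=O)N1C(C)C)Nc1ccc(Cl)c(Cl)c1`: > 1 h
- compound 2 `CN/C(=N\C1=NC(=O)C(=O)N1C(C)C)Nc1ccc(Cl)c(Cl)c1`: > 1 h

Compound 1 stands only at a limit of the assay, > 1 h, and not at a number. Among the compounds with values here, the series so far rests on (the limit of > 1 h in this assay, at which 2 of the 2 values shown sit).

Compound 3 `CC(C)N/C(=N\C1=NC(=O)C(=O)N1C(C)C)Nc1ccc(Cl)c(Cl)c1` differs from compound 1 as follows: isopropyl in place of ethoxy on an amine nitrogen. Within the data shown here, the only measured step on this amine nitrogen is a step that the two limits leave unreadable from compound 1 to compound 2, so it offers no size to carry over. In this assay no step beyond the scatter is expected, and no direction can be assigned. The expected step is a step that the limit leaves unreadable from compound 1 to compound 3. For compound 3 the estimated half-life is 1.5 h, with an expected range of 0.7 h to 3.5 h.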

Compound 3, half-life: > 1 h
Compound 3: only a limit was reported; the forecaster's own chance of this, stated with the estimate: 70%; the middle value does not contradict the limit.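

In this assay compound 3 gives > 1 h, a limit and not a number. Within the data shown here, no step among compound 1, compound 2 and compound 3 can be read. The actual half-life of each of these compounds stays open: the limit of > 1 h in this assay, at which 3 of the 3 values shown sit.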